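The source may report more compounds than this note shows. Statements on the series, on what has been measured and on what is new or still open speak of the compounds shown alone.

Measured compounds:
compound 1 `CN(CCN(C)C(=O)n1cccn1)Cc1ccc(OCc2ccccc2)cc1`: 530 nM
compound 2 `CN(CCN(C)C(=O)n1cc(C#N)cn1)Cc1ccc(OCc2ccccc2)cc1`: 320 nM
compound 3 `CN(CCN(C)C(c1ccc(OCc2ccccc2)cc1)c1ccc(OCc2ccccc2)cc1)C(=O)n1cccn1`: > 1000000 nM

In an assay on membranes from brain for binding affinity to Monoacylglycerol lipase ABHD6 (Mus musculus), read by fluorescence, with stated times of 1 h and 30 min (a lower number here means a stronger inhibitor, a higher number a weaker inhibitor), compound 1 gives 530 nM and compound 2 gives 320 nM. The change between them is cyano in place of hydrogen on an aromatic carbon, and the step it made is a 1.7-fold lower number from compound 1 to compound 2 (0.22 log units; within the scatter). In this assay compound 3 gives > 1000000 nM, which is a limit of the assay and not a number. How the core of compound 3 differs from the core of compound 1 is not broken down here. Compound 4 `CN(CCN(C)C(c1ccc(OCc2ccccc2)cc1)c1ccc(OCc2ccccc2)cc1)C(=O)n1cc(C#N)cn1` is not yet measured in this assay; it differs from compound 3 by cyano in place of hydrogen on an aromatic carbon, the same change as from compound 1 to compound 2, with the place described in the same words. That earlier step stayed within the scatter. Compound 4 is therefore expected to give about 1000000 nM, between 300000 nM and 3000000 nM, because the limit of > 1000000 nM in this assay, at which 1 of the 3 values shown sits, is where compound 3 sits. The expected step is a number no higher from compound 3 to compound 4 (the limit leaves the size open), most likely again reported only as a limit.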

Compound 4, half-maximal inhibitory concentration: > 1000000 nM
Compound 4 gave a limit, no number; the forecaster's own chance of this, stated with the estimate: 80%; the middle value sits exactly at the limit.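

In this assay compound 3 gives > 1000000 nM, a limit and not a number. For the compounds shown here, compound 4 gives > 1000000 nM, also a limit, so no step from compound 3 to compound 4 can be read. The compounds shown leave open what size of effect, if any, cyano in place of hydrogen has on the core of compound 3.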